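From benzyloxy to (4-chlorophenoxy)methyl on the shared core

The compounds below may be only part of what the source reports. "The series", "measured", "known", "first", "only" and "open" are said of these compounds alone.

Measured so far in a functional assay on HepG2 cells (Homo sapiens) for inhibition, read by MTT assay, with a stated time of 48 h; a higher number here means a weaker inhibitor, a lower number a stronger inhibitor:
- compound 1 `CS(=O)(=O)Nc1ccc(-n2cc(OCc3ccccc3)nn2)cc1Oc1ccccc1`: 12300 nM
- compound 2 `CS(=O)(=O)Nc1ccc(-n2cc(COc3ccc4ccccc4c3)nn2)cc1Oc1ccccc1`: 19500 nM

Within the data shown here, only two numbers are available. Compound 1 stands at 12300 nM, and compound 2 lies within the scatter of it at 19500 nM, so this assay does not separate the two. Among the measured compounds shown here, no pair of measured compounds differs in one place, which leaves no measured step to draw on.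

The next compound is compound 3 `CS(=O)(=O)Nc1ccc(-n2cc(COc3ccc(Cl)cc3)nn2)cc1Oc1ccccc1`. It carries (4-chlorophenoxy)methyl in place of benzyloxy on an aromatic carbon of the five-membered aromatic ring with 3 nitrogen ((4-chlorophenoxy)methyl in place of benzyloxy on an aromatic carbon). For the measured compounds named here, the only guide is that the side groups of compound 1 and compound 2 differ while their values stay within the scatter of each other. On that basis, no change beyond the scatter is expected in this assay. The expected step is a 1.1-fold higher number from compound 1 to compound 3 (0.06 log units; within the scatter). Compound 3 is estimated at 14000 nM, with an expected range from 7000 nM to 28000 nM.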

Compound 3, half-maximal inhibitory concentration: 7500 nM
Compound 3: the middle estimate sits 1.9-fold (0.27 log units) above what was measured, within the range that was stated.
By their numbers in this assay, from the lowest: compounds 3, 1 and 2 (each within the scatter of the next, the first and the last beyond it).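

In this assay, (4-chlorophenoxy)methyl in place of benzyloxy on an aromatic carbon of the five-membered aromatic ring with 3 nitrogen gives a 1.6-fold lower number from compound 1 to compound 3 (0.21 log units; within the scatter), so this change does not separate the two compounds. Among these compounds, with the oxygen on a saturated carbon kept, 4-chlorophenyl in place of naphthalen-2-yl gives a 2.6-fold lower number from compound 2 to compound 3 (0.41 log units; beyond the scatter), a modest step and the only one so far that lies beyond the scatter, which makes the aromatic group on that oxygen the first part of the side chain seen to shift the number in this assay. No measurement at hand bears on why this exchange shifts the number.

Open, from the compounds shown here alone, is whether the chlorine of the 4-chlorophenyl group has any part in this step, which a plain phenyl, a 4-fluorophenyl or a 4-methoxyphenyl on the same oxygen would test against compound 3. Also open, going by these compounds, is how this aromatic carbon responds to a side chain of another kind, such as an amine, a carboxylic acid or a longer chain ending in a phenyl ring.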